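Swapping 3,4-dimethoxyphenyl for 3,4-dichlorophenyl

The source may hold more compounds than are shown below. What is called first, only, known or untested is meant among the compounds shown, and "the series" means these compounds.

In a functional assay on FM3A cells (Mus musculus) for antiproliferative activity (a lower number here means a stronger inhibitor, a higher number a weaker inhibitor), compound 1 `COc1ccc(-c2cc(N)c(C(=O)c3cc(OC)c(OC)c(OC)c3)s2)cc1OC` gives 72 nM and compound 2 `COc1cc(C(=O)c2sc(-c3ccc(Cl)cc3)cc2N)cc(OC)c1OC` gives 90 nM, two values within the scatter of each other. Compound 3 `COc1cc(C(=O)c2sc(-c3ccccc3)cc2N)cc(OC)c1OC` gives 13 nM, the lowest of the three, so compound 1 stands with compound 2 at the upper end of this small set.

Compound 4 `COc1cc(C(=O)c2sc(-c3ccc(Cl)c(Cl)c3)cc2N)cc(OC)c1OC` awaits measurement. It has 3,4-dichlorophenyl in place of 3,4-dimethoxyphenyl, on an aromatic carbon next to the ring sulfur: 3,4-dichlorophenyl in place of 3,4-dimethoxyphenyl on an aromatic carbon.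

Among the compounds with values here, the closest precedent is the change to a single chloro group, a 1.3-fold higher number from compound 1 to compound 2 (0.10 log units; within the scatter). Removing that chloro group gives a 6.9-fold lower number from compound 2 to compound 3 (0.84 log units; beyond the scatter), and the unsubstituted phenyl compares with the dimethoxy compound as a 5.5-fold lower number from compound 1 to compound 3 (0.74 log units; beyond the scatter). Substituted rings thus sit together in this set, away from the plain phenyl. Within the data shown here, no measured step adds a second chloro group, so that part remains untested.

No step beyond the scatter is therefore expected in this assay. The expected step is a 1.3-fold higher number from compound 1 to compound 4 (0.12 log units; within the scatter). For compound 4 the estimated value is 95 nM, with an expected range of 35 nM to 250 nM.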

Compound 4, half-maximal inhibitory concentration: 400 nM
Compound 4: middle estimate off by 4.2-fold (0.62 log units), on the low side; measured number above the stated range.
By their numbers in this assay, from the lowest: compound 3; then compounds 1 and 2 (each within the scatter of the next); then compound 4.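

In this assay, the aromatic carbon next to the ring sulfur proves sensitive to a second chloro group: adding it gives a 4.4-fold higher number from compound 2 to compound 4 (0.65 log units; beyond the scatter), although compound 1 and compound 2 had stood within the scatter of each other. Substituted rings therefore do not form a single level, since 3,4-dichlorophenyl in place of 3,4-dimethoxyphenyl gives a 5.6-fold higher number from compound 1 to compound 4 (0.74 log units; beyond the scatter), while the same ring in place of phenyl gives a 31-fold higher number from compound 3 to compound 4 (1.49 log units; beyond the scatter), the largest step in the set. No evidence is available to explain this rise in the number.

Open, on these data alone, is whether the rise belongs to chloro specifically or would follow any second substituent on the phenyl ring. As far as these compounds go, how a fluoro group, a methyl group, an amine or a carboxylic acid on that ring would read in this assay also remains open.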